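The source may report more compounds than this note shows. Statements on the series, on what has been measured and on what is new or still open speak of the compounds shown alone.

Measured so far: compound 1 `C=CC(=O)N1CCCC(n2nc(-c3ccc(Oc4ccccc4)cc3)cc2C(=O)OCC)C1` gives 44000 nM in a functional assay on Z-138 cells (Homo sapiens) for inhibition, read by luminescence and CellTiter-Glo, with a stated time of 72 h; on this read-out lower numbers stand for stronger inhibition and higher numbers for weaker inhibition; compound 2 `C/C=C/C(=O)Nc1cccc(Cn2nc(-c3ccc(Oc4ccccc4)cc3)cc2C(=O)O)c1` gives 24100 nM; compound 3 `C/C=C/C(=O)N1CCCC(n2nc(-c3ccc(Oc4ccccc4)cc3)cc2C(=O)O)C1` gives only a limit, > 60000 nM, not a number.

Among the compounds with values here, compound 2 thus stands within the scatter of compound 1, and no compound here can be set apart from the others.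

Compound 4 `C/C=C/C(=O)Nc1cccc(Cn2nc(-c3ccc(Oc4ccccc4)cc3)cc2C(=O)OCC)c1` is the next step from compound 2: ethyl in place of hydrogen on an oxygen next to a carbonyl group. Within the data shown here, no pair among the measured compounds shows this single change by itself, so its effect is unknown. Because compound 1, which also carries an ethoxycarbonyl, gives 44000 nM, the step from compound 2 to compound 4 is expected to stay within the scatter, a 1.1-fold lower number from compound 2 to compound 4 (0.04 log units; within the scatter). Compound 4 is therefore estimated at 22000 nM, between 7000 nM and 60000 nM.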

Compound 4, half-maximal inhibitory concentration: 8900 nM
Beside the measured number, compound 4's estimate is 2.5-fold (0.39 log units) above it; low and high end bracket the measured number.
By their numbers in this assay, from the lowest: compound 4; then compounds 2 and 1 (each within the scatter of the next). At a limit, above all of these: compound 3.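

In this assay, within the data shown here, the change from carboxy to ethoxycarbonyl gives a 2.7-fold lower number from compound 2 to compound 4 (0.43 log units; beyond the scatter) and so is the first single change here whose effect can be read on its own. It shows that the number responds to what sits on this oxygen next to a carbonyl group, with the ethyl form giving the lower number. Nothing measured here explains this step. Open, as far as these compounds go, is how a methyl or a longer chain in place of the ethyl would compare, and how an amine-derived amide at this carbonyl would read.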